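Hydroxyl-Bearing Groups in Place of tert-Butyl

A few compounds are considered here, and "the series" means these few. Any claim that something is new, unique, unknown or untested is made for them only; others in the source may bear on it.

Compound 1 `CC(C)(C)c1cn(CCNc2nonc2/C(=N/O)Nc2ccc(F)c(Br)c2)nn1` is the reference of this set. Among the measured compounds shown here, in an assay on isolated protein for inhibition of Indoleamine 2,3-dioxygenase 1 (Homo sapiens) (a lower number here means a stronger inhibitor, a higher number a weaker inhibitor), compound 1 gives 132 nM, the highest of the three numbers measured so far. Compound 2 `OCCCc1cn(CCNc2nonc2/C(=N/O)Nc2ccc(F)c(Br)c2)nn1` gives 98 nM, and compound 3 `CC(C)CC(C)(O)c1cn(CCNc2nonc2/C(=N/O)Nc2ccc(F)c(Br)c2)nn1` gives 51 nM. The two steps from the reference are a 1.3-fold lower number from compound 1 to compound 2 (0.13 log units; within the scatter) and a 2.6-fold lower number from compound 1 to compound 3 (0.41 log units; beyond the scatter); between the two hydroxyl-bearing analogues the step is a 1.9-fold lower number from compound 2 to compound 3 (0.28 log units; within the scatter).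

Compound 4 `O/N=C(\Nc1ccc(F)c(Br)c1)c1nonc1NCCn1cc(C2(O)CCCCC2)nn1` is not yet measured. It differs from compound 1 as follows: 1-hydroxycyclohexyl in place of tert-butyl on an aromatic carbon. For the measured compounds named here, of the measured steps, the one from compound 1 to compound 3 bears most directly on it, since 1-hydroxy-1,3-dimethylbutyl and 1-hydroxycyclohexyl both carry a hydroxyl and are both larger than tert-butyl; that step was modest but beyond the scatter. The step to the 3-hydroxypropyl analogue, compound 2, stayed within the scatter, so a hydroxyl alone did not guarantee a change. A modest lowering of the number is therefore expected for compound 4, of about the size seen for compound 3, though a result within the scatter of compound 1 cannot be excluded; the expected step is a 2.2-fold lower number from compound 1 to compound 4 (0.34 log units; beyond the scatter). The estimate for compound 4 in this assay is 60 nM, with a range from 30 nM to 130 nM.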

Compound 4, half-maximal inhibitory concentration: 62 nM
The estimate for compound 4 lay 1.0-fold (0.01 log units) below the measured number; measured number inside the range.
By their numbers in this assay, from the lowest: compounds 3, 4, 2 and 1 (each within the scatter of the next, the first and the last beyond it).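

In this assay, 1-hydroxycyclohexyl on this aromatic carbon gives a second replacement of tert-butyl with a step beyond the scatter (a 2.1-fold lower number from compound 1 to compound 4 (0.33 log units; beyond the scatter)), so the modest gain seen with compound 3 no longer rests on a single group. The ring and the open-chain group are not separated at this position (a 1.2-fold higher number from compound 3 to compound 4 (0.08 log units; within the scatter)), which means that closing the carbons into a six-membered ring of carbon only leaves the number within the scatter of the 1-hydroxy-1,3-dimethylbutyl analogue. Compound 4 is also not separated from the 3-hydroxypropyl analogue (a 1.6-fold lower number from compound 2 to compound 4 (0.20 log units; within the scatter)), so the three hydroxyl-bearing groups cannot be placed in an order, and nothing available bears on the reason for any of these steps.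

A plain cyclohexyl group at this position would show how much of the step from tert-butyl goes with the ring and how much with the hydroxyl, since the two enter together in compound 4. Going by these compounds, how an amine or a carboxylic acid in place of the hydroxyl on the same ring carbon would read also stays open.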